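Swapping 4-methoxyphenyl for pyridin-2-yl at the assay limit

The compounds below may be only part of what the source reports. "The series", "measured", "known", "first", "only" and "open" are said of these compounds alone.

Three close relatives share one core and differ in the group on a saturated chain carbon bound to an aromatic nitrogen: compound 1 `CCOC(=O)c1ccc(-c2nn(Cc3ccc(Cl)cc3)c3ccccc23)cc1`, compound 2 `CCOC(=O)c1ccc(-c2nn(Cc3ccccc3F)c3ccccc23)cc1` and compound 3 `CCOC(=O)c1ccc(-c2nn(Cc3ccc(OC)cc3)c3ccccc23)cc1`. All three were tested in a functional assay on cells (Platelet, Homo sapiens) for inhibition; on this read-out lower numbers stand for stronger inhibition and higher numbers for weaker inhibition. Compound 1 gives > 10000 nM, which is a limit. Compound 2 gives > 10000 nM, also a limit. Compound 3 gives > 10000 nM, again a limit. Compound 3 therefore stands with the other two, at the limit of > 10000 nM in this assay, at which 3 of the 3 values shown sit.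

In compound 4 `CCOC(=O)c1ccc(-c2nn(Cc3ccccn3)c3ccccc23)cc1`, pyridin-2-yl stands in place of 4-methoxyphenyl on a saturated chain carbon bound to an aromatic nitrogen: pyridin-2-yl in place of 4-methoxyphenyl on a saturated chain carbon bound to an aromatic nitrogen. Going by the values given here, three measured steps bear on this change: a step that the two limits leave unreadable from compound 1 to compound 2, a step that the two limits leave unreadable from compound 1 to compound 3 and a step that the two limits leave unreadable from compound 2 to compound 3. None of them has a readable size or direction, and none shows a gain in this assay. The estimated step is therefore a step that the limit leaves unreadable from compound 3 to compound 4, with no change expected beyond the scatter. Compound 4 is expected to stay close to the limit, with an estimated value of 15000 nM and an expected range of 6000 nM to 40000 nM.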

Compound 4, half-maximal inhibitory concentration: > 10000 nM
Compound 4: no number, only a limit; the forecaster's own chance of this, stated with the estimate: 85%; the middle value does not contradict the limit.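

Compound 4 also gives only a limit, so its steps from compound 1, compound 2 and compound 3 cannot be read, and all four compounds stand together: the limit of > 10000 nM in this assay, at which 4 of the 4 values shown sit.

The compounds shown leave open which change to the shared core, if any, would give a measurable value in this assay.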